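A few compounds are considered here, and "the series" means these few. Any claim that something is new, unique, unknown or untested is made for them only; others in the source may bear on it.

In a functional assay on cells (Homo sapiens), read by thymidine incorporation (on this read-out higher numbers stand for weaker inhibition and lower numbers for stronger inhibition), compound 1 `Brc1cnn2c(NCc3cccnc3)cc(C3CC3)nc12` gives 1500 nM, while compound 2 `Brc1cnn2c(NCc3cccnc3)cc(C3CCCNC3)nc12` gives 60 nM, the lower of the two numbers and so the stronger inhibition. Compound 3 `Brc1cnn2c(NCc3cccnc3)cc(C3CCNCC3)nc12` keeps the shared core and the ((pyridin-3-yl)methyl)amino group, and the one alteration is this: piperidin-4-yl in place of piperidin-3-yl on an aromatic carbon. The two compounds have the same atoms, joined differently.

Within the data shown here, only one measured step bears on this change, and only indirectly. That step, a 25-fold lower number from compound 1 to compound 2 (1.40 log units; beyond the scatter), is large and beyond the scatter, and it shows that swapping the group at this place can move the number a long way in this pair. However, it replaces cyclopropyl with piperidin-3-yl, so it says nothing directly about piperidin-3-yl against piperidin-4-yl, and no measured pair makes that comparison. With no evidence for a direction, the expected change in this assay is small, a 1.2-fold higher number from compound 2 to compound 3 (0.07 log units; within the scatter), and no step beyond the scatter is expected. Among the measured compounds shown here, the large size of the one measured step argues for a wide range. Compound 3 is estimated at 70 nM, with an expected range from 20 nM to 300 nM.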

Compound 3, half-maximal inhibitory concentration: 160 nM
Estimate against measurement, compound 3: 2.3-fold (0.36 log units) below, and the stated range covers the measured number.
By their numbers in this assay, from the lowest: compound 2; then compound 3; then compound 1.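

In this assay, the same atoms joined differently still shift the number: piperidin-4-yl in place of piperidin-3-yl gives a 2.7-fold higher number from compound 2 to compound 3 (0.43 log units; beyond the scatter) and so lies beyond the scatter, which means that the point where the six-membered ring joins the shared core matters, and not just which atoms the group contains. Among these compounds, the gain over cyclopropyl is also not unique to piperidin-3-yl, as piperidin-4-yl gives a 9.4-fold lower number from compound 1 to compound 3 (0.97 log units; beyond the scatter) even though this step is smaller than the one to compound 2. Nothing available here explains why the two attachment points differ.

The compounds shown leave open whether the nitrogen of the piperidinyl ring is needed at all, a question that a cyclohexyl group, the same ring made of carbon alone, could help to answer. They also leave open how an open-chain amine such as 2-aminoethyl, or a 1-methylpiperidin-4-yl group with a methyl on that nitrogen, would compare at this place.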